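Notes on a dichlorophenyl swap in the series

A few compounds are considered here, and "the series" means these few. Any claim that something is new, unique, unknown or untested is made for them only; others in the source may bear on it.

Values in a physicochemical assay for lipophilicity, measured as octanol-water partition (on this read-out lower numbers stand for lower lipophilicity and higher numbers for higher lipophilicity), so far:
compound 1 `O=C(NNc1ccnc2cc(Cl)ccc12)c1ccccc1/N=C/c1ccc(F)cc1`: 5.18
compound 2 `O=C(NNc1ccnc2cc(Cl)ccc12)c1ccccc1/N=C/c1ccccc1Cl`: 5.5
compound 3 `O=C(NNc1ccnc2cc(Cl)ccc12)c1ccccc1/N=C/c1cccc(Cl)c1Cl`: 6.1

Of the three numbers, compound 3 has the highest at 6.1 in this assay on the measurements so far. Its nearest neighbour is reached by a number 0.60 log units higher from compound 2 to compound 3 (beyond the scatter) and its furthest by a number 0.92 log units higher from compound 1 to compound 3 (beyond the scatter) with both steps beyond the scatter.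

Compound 4 `O=C(NNc1ccnc2cc(Cl)ccc12)c1ccccc1/N=C/c1ccc(Cl)cc1Cl` carries 2,4-dichlorophenyl in place of 2,3-dichlorophenyl on a carbon with a double bond to nitrogen and has the same atoms joined differently.

The measured steps all change which halogens are present or how many. Adding a chloro in place of hydrogen gave a number 0.60 log units higher from compound 2 to compound 3 (beyond the scatter) and the change of aryl group gave a number 0.32 log units higher from compound 1 to compound 2 (beyond the scatter) as modest steps. For the measured compounds named here, no measured pair keeps the same atoms, so the data offer no direct size for this change. With the chlorine count unchanged, no step beyond the scatter is expected, and the estimated change is no change at the digits printed from compound 3 to compound 4 (within the scatter) for now. Compound 4 is estimated at 6.1 within an expected range of 5.75 to 6.4 on current data.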

Compound 4, partition coefficient: 6.22
Compound 4: the middle estimate sits 0.12 log units below what was measured; measured number inside the range.
By their numbers in this assay, from the lowest: compound 1; then compound 2; then compounds 3 and 4 (each within the scatter of the next).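

In this assay, for the compounds shown here, the first pair with the same atoms joined differently gives a number 0.12 log units higher from compound 3 to compound 4 (within the scatter), so at this position on a carbon with a double bond to nitrogen, 2,4-dichlorophenyl and 2,3-dichlorophenyl are not separated by this read-out. The chloro in place of hydrogen now has two readings, a number 0.60 log units higher from compound 2 to compound 3 (beyond the scatter) and a number 0.72 log units higher from compound 2 to compound 4 (beyond the scatter), and both dichlorophenyl compounds stand clear of the compound with one chlorine. The change of aryl group also yields the first step printed as large, a number 1.04 log units higher from compound 1 to compound 4 (beyond the scatter).

No measurement shown here bears on the reason for these steps. Still open, from the compounds shown here alone, is whether an amine or a carboxylic acid on this aryl ring would follow the same placement-independent reading, since all four compounds carry only halogens there.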